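From a Dimethylamino Chain to a Hydroxyethyl Arm

The source may hold more compounds than are shown below. What is called first, only, known or untested is meant among the compounds shown, and "the series" means these compounds.

Of the compounds shown here, two have been measured so far in an ADME assay on Vero cells (Chlorocebus sabaeus) for cytotoxicity, with a stated time of 72 h; on this read-out lower numbers stand for higher toxicity in this test and higher numbers for lower toxicity in this test. Compound 1 `CN(C)CCCc1ccc(C(=O)/C=C/c2ccc(Cl)cc2)cc1` gives 5.92 ug/mL in this assay. Compound 2 `CN(C)CCCNc1ccc(C(=O)C2CC2c2ccc(Cl)cc2)cc1` gives 15.8 ug/mL in this assay, the highest of the two numbers; compound 1 shows a lower number, and that gap lies beyond the usual scatter of the test. Compound 3 `O=C(c1ccc(NCCO)cc1)C1CC1c1ccc(Cl)cc1` has not yet been measured in this assay. It differs from compound 2 in one place: hydroxy in place of (dimethylamino)methyl on a saturated chain carbon, two bonds along the chain from a nitrogen on an aromatic ring. Among the compounds with values here, no pair of measured compounds isolates this change, so the measured compounds themselves show nothing about how this assay responds to it. The step of a 1.4-fold higher number from compound 2 to compound 3 (0.14 log units; within the scatter) is therefore an estimate only; it is expected to be modest and directed toward a higher number, although a result that stays within the scatter would not be surprising. On that basis compound 3 is estimated at 22 ug/mL in this assay, with a range running from 8 ug/mL to 60 ug/mL.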

Compound 3, half-maximal cytotoxic concentration: 305 ug/mL
Beside the measured number, compound 3's estimate is 14-fold (1.14 log units) below it, outside the stated range (above it).
By their numbers in this assay, from the lowest: compound 1; then compound 2; then compound 3.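

In this assay, putting hydroxy in place of (dimethylamino)methyl on a saturated chain carbon, two bonds along the chain from a nitrogen on an aromatic ring, gives a 19-fold higher number from compound 2 to compound 3 (1.29 log units; beyond the scatter), a large move that lies well beyond the scatter of the test. Within the data shown here, the earlier compounds held no pair that isolated any single change, so this is the first sign that the read-out responds strongly at this position, with the toxicity in this test falling sharply as the (3-(dimethylamino)propyl)amino arm gives way to the (2-hydroxyethyl)amino arm. Nothing measured here accounts for the size of this step.

Two things change together in this step, the end group and the length of the chain, and the pair of compounds cannot tell their shares apart. A 3-hydroxypropyl chain or a 2-(dimethylamino)ethyl chain in the same place would separate the two, and a carboxylic acid or a primary amine at the chain end would show whether the high number is particular to hydroxy.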